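Nitro for methoxy: cytotoxicity notes on the series

This account rests on a few compounds, and the source may have more. Where it says the series, first, only, none or still open, it means among the compounds named here.

Compound 1 `COc1ccc(CSc2nc(Cc3cccc(Br)c3)c(C)c(=O)[nH]2)cc1` and compound 2 `Cc1c(Cc2cccc(Br)c2)nc(SCc2ccc([N+](=O)[O-])cc2)[nH]c1=O` share one core and differ by a single change, (nitro in place of methoxy on an aromatic carbon). In an ADME assay on MT4 cells (Homo sapiens) for cytotoxicity, read by MTT assay (on this read-out higher numbers stand for lower toxicity in this test and lower numbers for higher toxicity in this test), compound 1 gives > 290000 nM, which is a limit of the test and not a number. In this assay compound 2 gives > 280000 nM, likewise a limit. The step that the two limits leave unreadable from compound 1 to compound 2 therefore cannot be sized from these two. Compound 3 `CCc1c(Cc2cc(C)cc(C)c2)nc(SCc2ccc(OC)cc2)[nH]c1=O` carries a different core; how it differs from compound 1 is not broken down here. In this assay compound 3 gives > 317000 nM, again a limit. All three values sit at the edge of the test: the limit of > 280000 nM in this assay, at which 1 of the 3 values shown sits, (the limit of > 290000 nM in this assay, at which 1 of the 3 values shown sits), (the limit of > 317000 nM in this assay, at which 1 of the 3 values shown sits).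

Compound 4 `CCc1c(Cc2cc(C)cc(C)c2)nc(SCc2ccc([N+](=O)[O-])cc2)[nH]c1=O` has not yet been measured. It stands to compound 3 as compound 2 stands to compound 1: nitro in place of methoxy on an aromatic carbon. The surroundings of the change read the same in both pairs, so this is the same change carried onto another core. Since the first instance could not be read, the expectation for compound 4 rests on the limits alone. The step is expected as an at least 1.0-fold lower number from compound 3 to compound 4 (0.02 log units; that floor lies within the scatter), an estimate only, because the limit of > 317000 nM in this assay, at which 1 of the 3 values shown sits, and the limit of > 290000 nM in this assay, at which 1 of the 3 values shown sits, show both the parent of this pair and the nitro compound of the other pair at the limit. Compound 4 is expected at 300000 nM, with a range from 150000 nM to 600000 nM, and the result will most likely again be reported as a limit rather than a number.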

Compound 4, half-maximal cytotoxic concentration: > 305000 nM
Compound 4: only a limit was reported (the forecaster's own chance of this, stated with the estimate: 85%); middle value at least 1.0-fold (0.00 log units) away from the limit.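

In this assay compound 4 gives > 305000 nM, a limit and not a number. Compound 3 also stands at a limit, and the step between compound 3 and compound 4 cannot be read. The compounds shown leave open where the true values of all four lie, and whether nitro in place of methoxy changes the read-out at all on either core.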